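Bromo for Chloro Carried onto a Second Core

The compounds below may be only part of what the source reports. "The series", "measured", "known", "first", "only" and "open" are said of these compounds alone.

Compound 1 `O=C1C(=O)N(CN2CCN(c3ccnc4cc(C(F)(F)F)ccc34)CC2)c2cccc(Cl)c21` and compound 2 `O=C1C(=O)N(CN2CCN(c3ccnc4cc(C(F)(F)F)ccc34)CC2)c2cccc(Br)c21` share one core; compound 3 `NC(=S)N/N=C1\C(=O)Nc2cc(Cl)ccc21` and compound 4 `NC(=S)N/N=C1\C(=O)Nc2cc(Br)ccc21` share another, and the difference between the two cores is not broken down here. In an ADME assay on 184B5 cells (Homo sapiens) for cytotoxicity, read by sulforhodamine B assay, with a stated time of 48 h (on this read-out lower numbers stand for stronger inhibition of growth and higher numbers for weaker inhibition of growth), compound 1 gives 47400 nM and compound 2 gives 49700 nM. The change between them, (bromo in place of chloro on an aromatic carbon), made a 1.0-fold higher number from compound 1 to compound 2 (0.02 log units; within the scatter). In this assay compound 3 gives 40800 nM. Compound 4 carries the same kind of change, (bromo in place of chloro on an aromatic carbon), though here the place is meta to a fused ring and para to a fused ring rather than ortho to a fused ring and meta to a fused ring. Because a 1.0-fold higher number from compound 1 to compound 2 (0.02 log units; within the scatter) lay within the scatter, compound 4 is expected to show a step of a 1.0-fold higher number from compound 3 to compound 4 (0.01 log units; within the scatter). Compound 4 is therefore estimated at 42000 nM, with a range from 21000 nM to 84000 nM.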

Compound 4, concentration for 50% growth inhibition: 34900 nM
Beside the measured number, compound 4's estimate is 1.2-fold (0.08 log units) above it, and the stated range covers the measured number.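

In this assay, bromo in place of chloro on an aromatic carbon gave a 1.2-fold lower number from compound 3 to compound 4 (0.07 log units; within the scatter). On both cores the change left a step that cannot be told from the scatter, and the two steps agree with each other: the same change on two cores in this assay, a 1.0-fold higher number (0.02 log units; within the scatter) from compound 1 to compound 2 and a 1.2-fold lower number (0.07 log units; within the scatter) from compound 3 to compound 4, 1.2-fold (0.09 log units) apart, within the scatter of two such steps. Among the compounds shown here, this shows only that the exchange of these two halogens moved nothing measurable in these two pairs; the pairs differ in core and also in where the halogen sits, so it does not show that the result would hold on any other core or place.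

The compounds shown leave open how an amine or a methoxy group would read in place of the halogen. They also leave open whether fluoro would match chloro and bromo on either core.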